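A few compounds are considered here, and "the series" means these few. Any claim that something is new, unique, unknown or untested is made for them only; others in the source may bear on it.

Compound 1 `COc1cc(-c2cc(/C=C/C(=O)c3ccc(N)cc3)[nH]n2)cc(OC)c1OC` stands lowest of the two numbers in a functional assay on SK-MEL-28 cells (Homo sapiens) for cytotoxicity, read by sulforhodamine B assay, with a stated time of 48 h, tested at 10 uM; a higher number here means a weaker effect of the compound at the concentration tested, a lower number a stronger effect: compound 1 gives -57%. Compound 2 `COc1cc(-c2cc(/C=C/C(=O)c3ccc(Cl)c(Cl)c3)[nH]n2)cc(OC)c1OC` gives 73%, and the step of a number 130 percentage points higher from compound 1 to compound 2 (beyond the scatter) came with 3,4-dichlorophenyl in place of 4-aminophenyl on a carbonyl carbon. Compound 3 `COc1cc(-c2cc(/C=C/C(=O)c3ccc(F)c(F)c3)[nH]n2)cc(OC)c1OC` is not yet measured; it differs from compound 1 by 3,4-difluorophenyl in place of 4-aminophenyl on a carbonyl carbon. Among the compounds with values here, this change resembles the single measured step, which was large and upward, so a large rise in this assay is expected, though its exact size rests on one step only. Compound 3 is therefore expected to give 55%, between 5% and 90%. That would be an expected step of a number 112 percentage points higher from compound 1 to compound 3 (beyond the scatter).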

Compound 3, a percentage reported as activity, at one concentration (the size of the read-out at that concentration, not a potency): 32%
Compound 3: the middle estimate sits 23 percentage points above what was measured; low and high end bracket the measured number.
By their numbers in this assay, from the lowest: compound 1; then compound 3; then compound 2.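

In this assay, 3,4-difluorophenyl on the carbonyl carbon gives a number 89 percentage points higher from compound 1 to compound 3 (beyond the scatter), so the rise seen with 3,4-dichlorophenyl is not a single case. The two halogen-bearing groups still differ clearly at this position: a number 41 percentage points lower from compound 2 to compound 3 (beyond the scatter), which places 3,4-difluorophenyl between 4-aminophenyl and 3,4-dichlorophenyl. Nothing measured here explains these differences. Still open, as far as these compounds go, is whether the strong effect of compound 1 depends on its amine, which a plain phenyl or a 4-hydroxyphenyl on the same carbonyl carbon would help test.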